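The compounds below may be only part of what the source reports. "The series", "measured", "known", "first", "only" and "open" are said of these compounds alone.

The compounds measured in an ADME assay on MT2 cells (Homo sapiens) for cytotoxicity; a higher number here means that more compound is tolerated, a lower number that less compound is tolerated:
Compound 1, `CC(C)=CCOc1cc(Nc2ncnc(N)n2)ccc1Cl`, gives 48000 nM.
Compound 2, `CNc1ncnc(Nc2ccc(Cl)c(OCC=C(C)C)c2)n1`, gives 3100 nM.
Compound 3, `CC(C)=CCOc1cc(Nc2ncnc(N)n2)ccc1C#N`, gives 200 nM.

Compound 1 stands highest of the three numbers in this assay. Its nearest neighbour is compound 2, reached by a 15-fold lower number from compound 1 to compound 2 (1.19 log units; beyond the scatter), the change being methyl in place of hydrogen on a nitrogen on an aromatic ring. Furthest away is compound 3, reached by a 240-fold lower number from compound 1 to compound 3 (2.38 log units; beyond the scatter), the change being cyano in place of chloro on an aromatic carbon. Both steps lie beyond the scatter and both lower the number.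

Compound 4, `CC(C)=CCOc1cc(Nc2nccc(C)n2)ccc1Cl`, has not yet been measured in this assay. It differs from compound 1 in one place: 4-methylpyrimidin-2-yl in place of 4-amino-1,3,5-triazin-2-yl on a nitrogen on an aromatic ring. Among the measured compounds shown here, neither measured step alters the 4-amino-1,3,5-triazin-2-yl group, so no step bears on this change directly. What the two steps do show is that each single change made to compound 1 has lowered the tolerated concentration, one by a large amount and one by a very large amount. A lowering beyond the scatter is therefore expected for compound 4 as well, though a smaller one than the step to compound 3, and the expected step is a 3.2-fold lower number from compound 1 to compound 4 (0.51 log units; beyond the scatter). For compound 4 in this assay the expected value is 15000 nM, with a range from 4000 nM to 50000 nM.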

Compound 4, half-maximal cytotoxic concentration: 150 nM
For compound 4 the middle estimate is 100-fold (2.00 log units) above the measured one; measured number outside the range, below it.
By their numbers in this assay, from the lowest: compounds 4 and 3 (each within the scatter of the next); then compound 2; then compound 1.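

In this assay, the group on the nitrogen on an aromatic ring proves to be a place where a single exchange gives a large step, with a 320-fold lower number from compound 1 to compound 4 (2.51 log units; beyond the scatter) when 4-methylpyrimidin-2-yl replaces 4-amino-1,3,5-triazin-2-yl. The two groups have the same count of heavy atoms and each is one six-membered aromatic ring, so the step arises with ring size and heavy-atom count unchanged, while the entering group has fewer ring hetero atoms, no hydrogen-bond donor and fewer hydrogen-bond acceptors. Nothing measured here accounts for the size of this step.

The exchange alters the amino group, the methyl group and the ring nitrogens all at once, and the compounds shown leave open which of these differences carries the step; a 4-aminopyrimidin-2-yl group or a 4-methyl-1,3,5-triazin-2-yl group on the same nitrogen would begin to separate them. Also open, as far as these compounds go, is how the number would respond to a carboxylic acid or a longer chain on the group at this position.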